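A few compounds are considered here, and "the series" means these few. Any claim that something is new, unique, unknown or untested is made for them only; others in the source may bear on it.

In a functional assay on brain (Rattus norvegicus, strain Wistar) for inhibition (on this read-out lower numbers stand for stronger inhibition and higher numbers for weaker inhibition), three compounds that share one core and differ in a single group have been measured. Compound 1 `COc1ccc(-c2c(C)[nH]c(=O)n2C2CCCCC2)cc1` gives 20400 nM, compound 2 `CCCCCc1ccc(-c2c(C)[nH]c(=O)n2C2CCCCC2)cc1` gives 10600 nM and compound 3 `Cc1[nH]c(=O)n(C2CCCCC2)c1-c1ccc(C2CCCCC2)cc1` gives 28900 nM. Compound 3 therefore stands level with compound 1 within the scatter, while its number is higher than that of compound 2 by a modest margin.

The next structure, compound 4 `Cc1[nH]c(=O)n(C2CCCCC2)c1-c1ccc(Oc2ccccc2)cc1`, keeps the core and changes one group: phenoxy in place of cyclohexyl on an aromatic carbon. In words, phenoxy takes the place of cyclohexyl on an aromatic carbon. For the measured compounds named here, no measured compound carries phenoxy, so the evidence is indirect and comes from three exchanges at this same place. The step of a 1.9-fold lower number from compound 1 to compound 2 (0.28 log units; within the scatter) and the step of a 1.4-fold higher number from compound 1 to compound 3 (0.15 log units; within the scatter) both stayed within the scatter. Going by the values given here, only the step of a 2.7-fold higher number from compound 2 to compound 3 (0.44 log units; beyond the scatter) went beyond it, and that step was modest. Across methoxy, pentyl and cyclohexyl, the numbers thus remain close together, and no clear direction can be carried over to phenoxy. The expected change is therefore none beyond the scatter, with an estimated 1.4-fold lower number from compound 3 to compound 4 (0.16 log units; within the scatter). Compound 4 is estimated at 20000 nM, with an expected range from 8000 nM to 50000 nM.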

Compound 4, half-maximal inhibitory concentration: 7900 nM
Beside the measured number, compound 4's estimate is 2.5-fold (0.40 log units) above it, and the stated range ends above it.
By their numbers in this assay, from the lowest: compounds 4, 2, 1 and 3 (each within the scatter of the next, the first and the last beyond it).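

In this assay, the exchange at this position gives a step that the earlier ones did not settle: a 3.7-fold lower number from compound 3 to compound 4 (0.56 log units; beyond the scatter) separates two groups that each bring one six-membered ring, so the presence of such a ring does not alone fix the number here, and the aromatic ring and the oxygen change together in this exchange. The group on the oxygen also counts, as phenyl in place of methyl gives a 2.6-fold lower number from compound 1 to compound 4 (0.41 log units; beyond the scatter), while a 1.3-fold lower number from compound 2 to compound 4 (0.13 log units; within the scatter) leaves phenoxy level with pentyl, so two quite different groups, one a chain and one ring-bearing, are not told apart in this assay. No measurement shown here accounts for any of these differences.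

What the compounds shown leave open is whether the oxygen or the aromatic ring carries the step from cyclohexyl, which a phenyl group set directly on the aromatic carbon would separate. Also open, as far as these compounds go, is how a longer link such as benzyloxy, or a chlorine or a carboxylic acid on the phenoxy ring, would read at this position.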